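Acid analogue: chloro for cyano, expectation before measurement

The source may hold more compounds than are shown below. What is called first, only, known or untested is meant among the compounds shown, and "the series" means these compounds.

In an assay on cells for displacement of a labelled ligand from prostaglandin E2 receptor EP4 subtype (Homo sapiens), read by scintillation counting (a higher number here means a weaker inhibitor, a lower number a stronger inhibitor), compound 1 `COc1ccc(-c2ccc(OCc3cc(C(=O)NS(=O)(=O)c4cccs4)oc3C)cc2)cc1` gives 3.6 nM, and compound 3 `COc1ccc(-c2ccc(OCc3cc(C(=O)NS(=O)(=O)Cc4ccccc4)oc3C)cc2)cc1` gives 3 nM. Within the data shown here, the single measured step between them, a 1.2-fold lower number from compound 1 to compound 3 (0.08 log units; within the scatter), concerns the sulfonyl side of the shared core and stays within the scatter.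

Compound 2 `Cc1oc(C(=O)O)cc1COc1ccc(-c2ccc(C#N)cc2)cc1` gives 1500 nM in this assay. It stands highest of the three numbers, beyond the scatter from compound 1 and from compound 3 alike, and so is the weakest inhibitor among the measured compounds. Among the measured compounds shown here, compound 2 carries a carboxylic acid where compound 1 and compound 3 carry an acylsulfonamide, and a cyano where they carry a methoxy; no step isolates either of those changes, so what its gap to them shows cannot be split.

Compound 4 `Cc1oc(C(=O)O)cc1COc1ccc(-c2ccc(Cl)cc2)cc1` differs from compound 2 by chloro in place of cyano on an aromatic carbon. For the measured compounds named here, no measured step touches this position: the one measured step lies on the sulfonyl side and is within the scatter. Going by the values given here, there is thus no direct precedent, and the step of no change at the digits printed from compound 2 to compound 4 (within the scatter) is expected to be small, not clearly beyond the scatter, with a wide range. Compound 4 is therefore estimated at 1500 nM in this assay, between 400 nM and 5000 nM.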

Compound 4, inhibition constant: 1000 nM
Compound 4: middle estimate off by 1.5-fold (0.18 log units), on the high side; measured number inside the range.
By their numbers in this assay, from the lowest: compounds 3 and 1 (each within the scatter of the next); then compounds 4 and 2 (each within the scatter of the next).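

Among these compounds, the first step at this position comes from the 4-cyanophenyl to 4-chlorophenyl change on the carboxylic acid core: in this assay, chloro in place of cyano on an aromatic carbon gives a 1.5-fold lower number from compound 2 to compound 4 (0.18 log units; within the scatter). The earlier compounds shown here offered only a step on the sulfonyl side, whereas this one shows that, with the carboxylic acid in place, the position para to a large group accepts the exchange without a shift that can be told from repeat measurements, even though the triple bond and the hydrogen-bond acceptor of the cyano leave and a single chlorine enters. No measurement at hand bears on why the two groups give readings within the scatter of each other.

Among the compounds shown here, whether an amine or a trifluoromethyl at this same place would give a step beyond the scatter remains open, since cyano and chloro are the only two groups compared here on this core. For the compounds shown here, also open is whether chloro in place of cyano would give a similarly small step on a core carrying an acylsulfonamide, where no such pair is available.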